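The source may report more compounds than this note shows. Statements on the series, on what has been measured and on what is new or still open speak of the compounds shown alone.

Compound 1 `COc1cc(-c2nnc3n2NC(c2ccco2)C(C(=O)C2CC2)S3)cc(OC)c1OC` gives > 100000 nM in a functional assay on A549 cells (Homo sapiens) for cytotoxicity, read by MTT assay, with a stated time of 48 h (a lower number here means a stronger inhibitor, a higher number a weaker inhibitor), a limit of the assay rather than a number. Compound 2 `COc1cc(-c2nnc3n2NC(c2cccs2)C(C(=O)c2ccccc2)S3)cc(OC)c1OC` gives 69400 nM in this assay. Compound 3 `COc1cc(-c2nnc3n2NC(c2cccs2)C(C(=O)c2ccc(F)cc2)S3)cc(OC)c1OC` gives 45000 nM in this assay.

Compound 1 thus sits at the limit (the limit of > 100000 nM in this assay, at which 1 of the 3 values shown sits), while the other two compounds carry numbers. Compound 4 `COc1cc(-c2nnc3n2NC(c2ccco2)C(C(=O)c2ccc(C(F)(F)F)cc2)S3)cc(OC)c1OC` arises from compound 1 by 4-(trifluoromethyl)phenyl in place of cyclopropyl on a carbonyl carbon. Among the compounds with values here, no measured step shares this change. Within the data shown here, the one measured step, a 1.5-fold lower number from compound 2 to compound 3 (0.19 log units; within the scatter), concerns a substituent on an aromatic ring already present and says little about exchanging cyclopropyl for an aryl ring. Compounds 2 and 3, both bearing an aryl ketone, show numbers where compound 1 shows only a limit. Compound 4 is therefore expected to give a number, estimated at 50000 nM with a range of 20000 nM to 100000 nM. The expected step is an at least 2.0-fold lower number from compound 1 to compound 4 (0.30 log units; that floor lies within the scatter), though a limit remains possible.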

Compound 4, half-maximal inhibitory concentration: 37200 nM
Compound 4: the middle estimate sits 1.3-fold (0.13 log units) above what was measured, within the range that was stated.
By their numbers in this assay, from the lowest: compounds 4, 3 and 2 (each within the scatter of the next). At a limit, above all of these: compound 1.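

In this assay the exchange of cyclopropyl for 4-(trifluoromethyl)phenyl on a carbonyl carbon gives an at least 2.6-fold lower number from compound 1 to compound 4 (0.42 log units; beyond the scatter) and is the first step shown at this position. It is also the first step shown that lies beyond the scatter. Compound 1 holds a limit and not a number, so this step gives only a floor: the limit of > 100000 nM in this assay, at which 1 of the 4 values shown sits.

Going by these compounds, whether the step comes from the phenyl ring itself or from its trifluoromethyl group stays open. So does how an amine or a carboxylic acid on that ring would read in this assay.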